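Phenyl for neopentyl on the hydroxyacyl side chain

This account rests on a few compounds, and the source may have more. Where it says the series, first, only, none or still open, it means among the compounds named here.

Measured compounds:
compound 1, `CC(C)(C)C[C@@H](O)C(=O)N1[C@@H]2C[C@@H]2C[C@H]1C(=O)NCc1cc(Cl)ccc1-n1cnnn1`, 71 mL.min-1.g-1
compound 2, `O=C(NCc1cc(Cl)ccc1-n1cnnn1)[C@@H]1CCON1C(=O)[C@H](O)c1ccccc1`, < 12 mL.min-1.g-1
compound 3, `CC(C)(C)C[C@@H](O)C(=O)N1[C@H](C(=O)NCc2cc(Cl)ccc2-n2cnnn2)C[C@@H]2C[C@@H]21`, 40 mL.min-1.g-1

In an ADME assay on liver for metabolic stability, with Liver microsome (Homo sapiens) as the target, read by LC-MS, using microsomes (a higher number here means faster removal of the compound, a lower number slower removal), compound 1 gives 71 mL.min-1.g-1, the highest of the two numbers shown. Compound 3 lies nearest, and the step of a 1.8-fold lower number from compound 1 to compound 3 (0.25 log units; within the scatter) stays within the scatter, which fits the fact that (the fact that compounds 1 and 3 differ only in the configuration as drawn). Compound 2 is reported only as a limit in this assay, < 12 mL.min-1.g-1, and that limit is the limit of < 12 mL.min-1.g-1 in this assay, at which 1 of the 3 values shown sits.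

Compound 4, `O=C(NCc1cc(Cl)ccc1-n1cnnn1)[C@@H]1C[C@H]2C[C@H]2N1C(=O)[C@H](O)c1ccccc1`, is not yet measured. It differs from compound 1 by phenyl in place of neopentyl on a saturated chain carbon bound to a carbonyl carbon and an oxygen on a saturated carbon. Going by the values given here, no measured step covers this exact change on the shared core of compound 1; compound 2 carries the same phenyl-bearing side chain on a different core, and there only a limit is known. Because compound 2 sits at the limit of < 12 mL.min-1.g-1 in this assay, at which 1 of the 3 values shown sits, the number for compound 4 is expected to move downward. The expected step is a 3.2-fold lower number from compound 1 to compound 4 (0.51 log units; beyond the scatter), more than the scatter but with wide uncertainty. The estimate for compound 4 is 22 mL.min-1.g-1, within 8 mL.min-1.g-1 to 50 mL.min-1.g-1.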

Compound 4, intrinsic clearance in microsomes: < 15 mL.min-1.g-1
Compound 4: a limit, no number (the forecaster's own chance of this, stated with the estimate: 30%); middle value at least 1.4-fold (0.16 log units) from the limit.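

On the shared core of compound 1, the swap of neopentyl for phenyl on the saturated chain carbon now has a direct reading in this assay: an at least 4.7-fold lower number from compound 1 to compound 4 (0.67 log units; beyond the scatter). Going by these compounds alone, until now, the phenyl-bearing side chain had been seen only on the different core of compound 2. Compound 4 gives < 15 mL.min-1.g-1, which is a limit of the assay and not a number, so this side chain has now ended at a limit on both cores shown, as compound 2 did.

As far as these compounds go, how far compound 4 really lies beyond that limit remains open, so the full size of the step is unknown. From the compounds shown here alone, it is also open whether a cyclohexyl group, a saturated six-membered ring of carbon, at the same place would follow phenyl or neopentyl in this assay.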